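The source may report more compounds than this note shows. Statements on the series, on what has been measured and on what is new or still open speak of the compounds shown alone.

The two compounds with results come from the same series of antagonists of Toll-like receptor 8. Compound 1 `Cn1nc(-c2ccc(OC[C@H]3CC[C@H](N)CC3)c(F)c2)c2cnc(N)nc21` is the only one of them with an actual number: in an assay on THP-1 cells for antagonist activity at Toll-like receptor 8 (Homo sapiens) (on this read-out lower numbers stand for stronger inhibition and higher numbers for weaker inhibition), compound 1 gives 5 nM. Compound 2 `Cc1cc(-c2ccnc3[nH]ncc23)cnc1OCC12CCC(O)(CC1)CC2` is recorded differently, since in this assay compound 2 gives < 1 nM, which is a limit of the assay rather than a number. Going by the values given here, this is the situation described by the limit of < 1 nM in this assay, at which 1 of the 2 values shown sits, so compound 1 stands as the single measured value among the two.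

Compound 3 `Cn1nc(-c2ccc(OC[C@H]3CC[C@@H](N)CC3)c(F)c2)c2cnc(N)nc21` has not yet been measured. Against compound 1 the change is the two compounds have the same atoms and bonds and differ only in configuration as drawn: 2 of 2 stereo elements differ (all stereocentres are inverted: mirror images); a stereocentre at a saturated ring carbon is drawn r in compound 1 and s in compound 3; a stereocentre at a saturated ring carbon is drawn r in compound 1 and s in compound 3; in words, the two compounds have the same atoms and bonds and differ only in configuration as drawn, with both stereocentres at saturated ring carbons inverted, so that the two are mirror images. Among the compounds with values here, no step between measured compounds of this kind is available here, so the expectation rests on the change itself. A swap of ring configuration of this sort is expected to move potency only modestly, and the step from compound 1 to compound 3 is estimated at a 2.0-fold higher number from compound 1 to compound 3 (0.30 log units; within the scatter) toward weaker inhibition. Compound 3 is therefore expected to give about 10 nM in this assay, with a range from 3 nM to 40 nM.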

Compound 3, half-maximal inhibitory concentration: 20 nM
For compound 3 the middle estimate is 2.0-fold (0.30 log units) below the measured one, within the range that was stated.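

The result gives the only step between closely related compounds shown here: with atoms and bonds unchanged and both stereocentres at saturated ring carbons inverted, this assay shows a 4.0-fold higher number from compound 1 to compound 3 (0.60 log units; beyond the scatter). Configuration alone is therefore enough to shift this read-out beyond the usual scatter, and the form drawn in compound 1 gives the stronger inhibition of the pair. The step can be assigned to configuration and to nothing else because of one fact: the fact that compounds 1 and 3 differ only in the configuration as drawn

Going by these compounds, since both stereocentres change together, it stays open how much each contributes, and whether the same step would appear with a different group on the saturated ring, such as a carboxylic acid. Compound 2 differs from compound 1 and compound 3 in more than one place and its value is a limit rather than a number, so it adds nothing to this question: the limit of < 1 nM in this assay, at which 1 of the 3 values shown sits.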